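Compound 1 to compound 4: a fluorobenzyl change

The source may report more compounds than this note shows. Statements on the series, on what has been measured and on what is new or still open speak of the compounds shown alone.

In a functional assay on MCF7 cells (Homo sapiens) for cytotoxicity, read by MTT assay, with a stated time of 24 h (on this read-out lower numbers stand for stronger inhibition and higher numbers for weaker inhibition), compound 1 `COc1ccc(/C=C2\CN(C(=S)SCc3cn(Cc4ccccc4F)nn3)C/C(=C\c3ccc(OC)cc3)C2=O)cc1` gives 79400 nM and compound 3 `COc1ccc(/C=C2\CN(Cc3cn(Cc4cccc(Cl)c4)nn3)C/C(=C\c3ccc(OC)cc3)C2=O)cc1` gives 99000 nM as its nearest neighbour, within the scatter. Compound 2 `O=C1/C(=C/c2ccccc2F)CN(Cc2cn(Cc3ccccc3F)nn2)C/C1=C\c1ccccc1F` gives 6000 nM as the number furthest from compound 1, lower and beyond the scatter. Compound 1 therefore sits with compound 3 at the high end of the three numbers, and compound 2 stands apart.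

Going by the values given here, no two measured compounds differ in one place only, so no measured step speaks directly to the next change. Compound 4 `COc1ccc(/C=C2\CN(C(=S)SCc3cn(Cc4ccc(F)cc4)nn3)C/C(=C\c3ccc(OC)cc3)C2=O)cc1` differs from compound 1 by 4-fluorophenyl in place of 2-fluorophenyl on a saturated chain carbon bound to an aromatic nitrogen in the form of 4-fluorophenyl in place of 2-fluorophenyl on a saturated chain carbon bound to an aromatic nitrogen.

No step beyond the scatter is expected in this assay in either direction. Among the compounds with values here, that expectation is anchored on compound 1 at 79400 nM as the only measured compound sharing the rest of the structure, and the data hold no direct test of it. The estimate amounts to a 1.2-fold lower number from compound 1 to compound 4 (0.09 log units; within the scatter) as an expected step. For compound 4 the expected value is 65000 nM within an estimated range of 20000 nM to 130000 nM on this read-out.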

Compound 4, half-maximal inhibitory concentration: > 100000 nM
Compound 4 gave a limit, no number; the forecaster's own chance of this, stated with the estimate: 10%; middle value at least 1.5-fold (0.18 log units) from the limit.
By their numbers in this assay, from the lowest: compound 2; then compounds 1 and 3 (each within the scatter of the next). At a limit, above all of these: compound 4.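

In this assay, compound 4 gives only a limit, > 100000 nM, and not a number. Going by these compounds alone, the change from 2-fluorobenzyl to 4-fluorobenzyl is the first single-place comparison, and it reads as an at least 1.2-fold higher number from compound 1 to compound 4 (0.10 log units; that floor lies within the scatter). On the saturated chain carbon bound to an aromatic nitrogen, 4-fluorophenyl therefore brings no lower number than 2-fluorophenyl on the core of compound 1, while the true size of the step stays unknown, since only its floor can be read: the limit of > 100000 nM in this assay, at which 1 of the 4 values shown sits.

Open, from the compounds shown here alone, is how this position responds to groups other than the two fluorophenyl isomers, such as an unsubstituted benzyl, a longer chain such as phenethyl, or a benzyl carrying an amine or a carboxylic acid. Also open, going by these compounds, is whether the same exchange of 2-fluorophenyl for 4-fluorophenyl would give a readable step on a compound with a lower starting number, as the present pair ends at a limit and says nothing about the change elsewhere.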